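Arylsulfonyl variation on a pyrazoline series

The source may report more compounds than this note shows. Statements on the series, on what has been measured and on what is new or still open speak of the compounds shown alone.

Measured so far in a functional assay on NCI-H1975 cells (Homo sapiens) for inhibition, read by sulforhodamine B assay, tested at 10 uM; on this read-out lower numbers stand for less inhibition and higher numbers for more inhibition at the one concentration tested (going by the name of the read-out):
- compound 1 `CN(C)c1ccc(C2CC(c3ccc(-n4cncn4)cc3)=NN2)cc1`: -3.3%
- compound 2 `CN(C)c1ccc(C2CC(c3ccc(-n4cncn4)cc3)=NN2S(C)(=O)=O)cc1`: -3.1%

Compound 2 stands highest of the two numbers, but its nearest neighbour is compound 1, and the step of a number 0.2 percentage points higher from compound 1 to compound 2 (within the scatter) lies within the scatter, so the two values are not distinguishable. Both sit at the level of no inhibition at the single concentration tested.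

Compound 3 `CN(C)c1ccc(C2CC(c3ccc(-n4cncn4)cc3)=NN2S(=O)(=O)c2ccc(Br)cc2)cc1` is not yet measured. Against compound 2 it differs by 4-bromophenyl in place of methyl on a sulfonyl sulfur. For the measured compounds named here, the only measured step, that from compound 1 to compound 2, concerns methylsulfonyl in place of hydrogen on an amine nitrogen in a ring; it does not bear on the exchange of methyl for 4-bromophenyl on a sulfonyl sulfur, and it was flat. Going by the values given here, there is thus no measured step that points in either direction for compound 3, and nothing so far moved beyond the scatter.

For compound 3 the step of a number 7.1 percentage points higher from compound 2 to compound 3 (within the scatter) is expected to stay within the scatter. Compound 3 is estimated at 4%, with a range from -12% to 25%.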

Compound 3, a percentage reported as inhibition, at one concentration (the size of the read-out at that concentration, not a potency): -0.6%
Compound 3: middle estimate off by 4.6 percentage points, on the high side; the measured number falls inside the stated range.
By their numbers in this assay, from the lowest: compounds 1, 2 and 3 (each within the scatter of the next).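

In this assay, 4-bromophenyl in place of methyl on the sulfonyl sulfur gives a number 2.5 percentage points higher from compound 2 to compound 3 (within the scatter) and, measured against the unsubstituted ring nitrogen, (4-bromophenyl)sulfonyl gives a number 2.7 percentage points higher from compound 1 to compound 3 (within the scatter). For the compounds shown here, the earlier compounds showed only that a methylsulfonyl group on this nitrogen leaves the read-out unchanged; the new result extends that to an aromatic substituent on the sulfonyl sulfur, with 7 heavy atoms entering where 1 leaves, and still no readable change, so all three compounds stay at the level of no inhibition at the one concentration tested. No supporting data bear on why the read-out stays flat across these changes.

Because the 4-bromophenyl exchange brings in the aromatic ring and the bromine together, the compounds shown do not separate the two, and a plain phenyl or a 4-methoxyphenyl on the sulfonyl sulfur would be needed to tell them apart. On these data alone, it also remains open whether a substituent of a different kind at this place, such as an aminoalkyl chain or a group carrying a carboxylic acid, would lift the read-out clear of the scatter at all.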